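The source may report more compounds than this note shows. Statements on the series, on what has been measured and on what is new or still open speak of the compounds shown alone.

Working notes on the series in an ADME assay on Vero 76 cells (Chlorocebus sabaeus) for cytotoxicity, read by MTT assay, with a stated time of 96 h; a higher number here means that more compound is tolerated, a lower number that less compound is tolerated. Compound 1 `NS(=O)(=O)c1ccc(N2N=C(c3ccc(OCc4ccccc4)cc3)CC2c2ccccc2)cc1` gives > 100000 nM, which is a limit and not a number. Compound 3 `NS(=O)(=O)c1ccc(N2N=C(c3ccc(OCc4ccccc4)cc3)CC2c2ccccc2F)cc1` gives > 100000 nM, which is also a limit. For the measured compounds named here, compound 2 `NS(=O)(=O)c1ccc(N2N=C(c3ccc(OCc4ccccc4)cc3)CC2c2ccccc2Cl)cc1` gives 92000 nM, the only actual number so far. On these data alone, compound 3 therefore sits on (the limit of > 100000 nM in this assay, at which 2 of the 3 values shown sit), and its true value is unknown.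

The next change leads to compound 4 `NS(=O)(=O)c1ccc(N2N=C(c3ccc(OCc4ccccc4)cc3)CC2c2cccc(F)c2)cc1`: 3-fluorophenyl in place of 2-fluorophenyl on a saturated ring carbon. In words, 3-fluorophenyl stands in place of 2-fluorophenyl on a saturated ring carbon.

Going by the values given here, three measured steps bear on this: an at least 1.0-fold lower number from compound 1 to compound 2 (0.03 log units; that floor lies within the scatter), a step that the two limits leave unreadable from compound 1 to compound 3 and an at least 1.0-fold higher number from compound 2 to compound 3 (0.03 log units; that floor lies within the scatter). None of them shows a change beyond the scatter, and none involves the 3-fluorophenyl group, so the support is indirect. No step beyond the scatter is expected in this assay, in either direction. The expected step is a number no higher from compound 3 to compound 4 (the limit leaves the size open).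

For compound 4 the estimate is 100000 nM, with an expected range of 60000 nM to 150000 nM. A report of only a limit is the likeliest outcome.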

Compound 4, half-maximal cytotoxic concentration: 90000 nM
The estimate for compound 4 lay 1.1-fold (0.05 log units) above the measured number; the range from low to high includes it.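

In this assay, 3-fluorophenyl in place of 2-fluorophenyl on the saturated ring carbon gives an at least 1.1-fold lower number from compound 3 to compound 4 (0.04 log units; that floor lies within the scatter), so moving the fluoro on this phenyl ring yields a measured number but no step beyond the scatter. Compared with the 2-chlorophenyl group the result is a 1.0-fold lower number from compound 2 to compound 4 (0.01 log units; within the scatter), and compared with the plain phenyl group it is an at least 1.1-fold lower number from compound 1 to compound 4 (0.04 log units; that floor lies within the scatter), so all three halogen variants at this position remain within the scatter of what can be read. The real size of the step from the 2-fluorophenyl compound stays hidden behind a limit: the limit of > 100000 nM in this assay, at which 2 of the 4 values shown sit.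

On these data alone, whether a carboxylic acid, an amine or a methoxy group in place of the fluoro would give a step beyond the scatter remains open. As far as these compounds go, how far compound 1 and compound 3 lie past their limits also remains open.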